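A few compounds are considered here, and "the series" means these few. Any claim that something is new, unique, unknown or untested is made for them only; others in the source may bear on it.

Of the compounds shown here, three sharing one macrocyclic core have been tested in a functional assay on PANC-1 cells (Homo sapiens) for antiproliferative activity; a lower number here means a stronger inhibitor, a higher number a weaker inhibitor. Compound 1, `CC[C@H](C)[C@H]1C(=O)N[C@H](Cc2cc(Cl)c(O)c(Cl)c2)C(=O)N[C@@H](C(C)(C)O)C(=O)O[C@H](c2ccccc2)[C@H](C)/C=C/C=C(\C)[C@H](OC)C[C@@H]2O[C@@]2(C)C(=O)N1C`, gives 12.2 nM in this assay. Compound 2, `CC[C@H](C)[C@H]1C(=O)N[C@H](Cc2ccc(O)c(Br)c2)C(=O)N[C@@H](C(C)(C)O)C(=O)O[C@H](c2ccccc2)[C@H](C)/C=C/C=C(\C)[C@H](OC)C[C@@H]2O[C@@]2(C)C(=O)N1C`, gives 9.61 nM. Compound 3, `CC[C@H](C)[C@H]1C(=O)N[C@H](Cc2ccc(O)c(Br)c2)C(=O)N[C@@H](C(C)(C)O)C(=O)O[C@H](c2ccccc2)[C@H](C)/C=C/C=C(\C)[C@H](OC)C[C@H]2O[C@]2(C)C(=O)N1C`, reaches only the limit of this assay, > 200 nM, so for compound 3 there is a bound rather than a number.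

The step of a 1.3-fold lower number from compound 1 to compound 2 (0.10 log units; within the scatter) is small. The step of an at least 20-fold higher number from compound 2 to compound 3 (1.31 log units; beyond the scatter) is large; it rests on the fact that compounds 2 and 3 differ only in the configuration as drawn and on (the limit of > 200 nM in this assay, at which 1 of the 3 values shown sits).

Compound 4, `CC[C@H](C)[C@H]1C(=O)N[C@H](Cc2cc(Cl)c(O)c(Cl)c2)C(=O)N[C@@H](C(C)(C)O)C(=O)O[C@H](c2ccccc2)[C@H](C)/C=C/C=C(\C)[C@H](OC)C[C@H]2O[C@]2(C)C(=O)N1C`, is not yet measured. It differs from compound 3 as 3,5-dichloro-4-hydroxyphenyl in place of 3-bromo-4-hydroxyphenyl on a saturated chain carbon bound to a saturated ring carbon. Within the data shown here, the only measured step that bears on this change is a 1.3-fold lower number from compound 1 to compound 2 (0.10 log units; within the scatter), which runs in the opposite direction and stays within the scatter. The change in this assay is therefore expected to be small, with no direction beyond the scatter, so compound 4 should stand close to compound 3.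

Compound 4 is expected to show a step that the limit leaves unreadable from compound 3 to compound 4 in this assay. The estimate for compound 4 is 300 nM, with a range from 120 nM to 1500 nM, and it is quite likely that this assay again reports only a limit for compound 4 rather than a number.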

Compound 4, half-maximal inhibitory concentration: > 200 nM
Compound 4: only a limit was reported; the forecaster's own chance of this, stated with the estimate: 65%; the middle value lies beyond the limit too.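

In this assay compound 4 gives > 200 nM, which is a limit of the assay and not a number. The step of an at least 16-fold higher number from compound 1 to compound 4 (1.21 log units; beyond the scatter) shows that the large change seen earlier with 3-bromo-4-hydroxyphenyl also appears with 3,5-dichloro-4-hydroxyphenyl, so among these compounds it is not tied to one of the two groups, and the rise in the number traces to the two ring stereocentres alone: the fact that compounds 1 and 4 differ only in the configuration as drawn. The step between compound 3 and compound 4 cannot be read, as both stand at the same limit, so in this configuration the swap of the two groups shows no measurable effect in either direction: the limit of > 200 nM in this assay, at which 2 of the 4 values shown sit.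

The compounds shown leave open how far past the limit compound 3 and compound 4 truly lie, and whether the change comes from one of the two ring stereocentres or needs both. They also leave open how a phenyl carrying an amine or a carboxylic acid, placed on the same saturated chain carbon bound to a saturated ring carbon, would read in this assay in either configuration.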